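Swapping Imidazoline for Imidazole on a Naphthol Amine

The source may report more compounds than this note shows. Statements on the series, on what has been measured and on what is new or still open speak of the compounds shown alone.

Compound 1 `c1ccc(-c2ccno2)c(OCC2=NCCN2)c1`: 100 nM
Compound 2 `c1ccc(N2CCCCC2)c(NCC2=NCCN2)c1`: < 5020 nM
Compound 3 `Oc1ccc2cccc(NCC3=NCCN3)c2c1`: < 5020 nM

In a functional assay for activation of Alpha-1B adrenergic receptor (Homo sapiens) (on this read-out higher numbers stand for an effect only at larger amounts of compound and lower numbers for an effect already at smaller amounts), compound 1 gives 100 nM. For compound 2 only a limit of the assay is reported, < 5020 nM. Compound 3 likewise shows only a limit, < 5020 nM. So compound 3 has no exact number; it stands at the limit of < 5020 nM in this assay, at which 2 of the 3 values shown sit, and its true position is unknown.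

Compound 4 `Oc1ccc2cccc(NCc3c[nH]cn3)c2c1` differs from compound 3 by a group of 5 heavy atoms (3 carbon, 2 nitrogen; one five-membered aromatic ring with 2 hetero atoms) in place of a group of 5 heavy atoms (3 carbon, 2 nitrogen; one five-membered non-aromatic ring with 2 hetero atoms), on a saturated chain carbon bound to a nitrogen on an aromatic ring. No measured pair isolates this change, so its size and direction cannot be read from the data shown. Compound 4 is expected to give 2000 nM, with a likely range from 300 nM to 10000 nM. The expected step is a step that the limit leaves unreadable from compound 3 to compound 4, with a real chance that only a limit is reported again.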

Compound 4, half-maximal effective concentration: < 5020 nM
Compound 4: a limit, no number (the forecaster's own chance of this, stated with the estimate: 50%); the middle value does not contradict the limit.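

No step from compound 3 to compound 4 can be read, because each of the two compounds gives only a limit: the limit of < 5020 nM in this assay, at which 3 of the 4 values shown sit.

From the compounds shown here alone, whether the 1H-imidazol-4-yl group changes the effect at all in this assay stays open.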